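From dimethylamino to acetyl on a shared core

The source may report more compounds than this note shows. Statements on the series, on what has been measured and on what is new or still open speak of the compounds shown alone.

Values in a functional assay on HaCaT cells (Homo sapiens) for antiproliferative activity, read by sulforhodamine B assay, with a stated time of 3 days; a lower number here means a stronger inhibitor, a higher number a weaker inhibitor:
- compound 1 `CCOc1ccc(OC)cc1CCc1ccc(O)c(C(=O)OC)c1` gives 120 nM
- compound 2 `COC(=O)c1cc(CCc2cc(OC)ccc2Br)ccc1O` gives 210 nM
- compound 3 `COC(=O)c1cc(CCc2cc(OC)ccc2N(C)C)ccc1O` gives 650 nM

Compound 3 has the highest number of the three, which makes it the weakest inhibitor here. Compound 4 `COC(=O)c1cc(CCc2cc(OC)ccc2C(C)=O)ccc1O` differs from it in one place: acetyl in place of dimethylamino on an aromatic carbon, acetyl in place of dimethylamino, para to a methoxy group. Dimethylamino in place of ethoxy gave a 5.4-fold higher number from compound 1 to compound 3 (0.73 log units; beyond the scatter), and dimethylamino in place of bromo gave a 3.1-fold higher number from compound 2 to compound 3 (0.49 log units; beyond the scatter). Bromo in place of ethoxy gave a 1.8-fold higher number from compound 1 to compound 2 (0.24 log units; within the scatter). Acetyl itself is untested, so only a modest gain is expected in this assay. The expected change is a 2.2-fold lower number from compound 3 to compound 4 (0.34 log units; beyond the scatter). For compound 4 the estimated value is 300 nM, with an expected range from 100 nM to 900 nM.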

Compound 4, half-maximal inhibitory concentration: 41 nM
For compound 4 the middle estimate is 7.3-fold (0.86 log units) above the measured one; measured number outside the range, below it.
By their numbers in this assay, from the lowest: compound 4; then compounds 1 and 2 (each within the scatter of the next); then compound 3.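

In this assay, the position para to a methoxy group can do better than ethoxy, which none of the earlier groups did. Acetyl in place of dimethylamino gives a 16-fold lower number from compound 3 to compound 4 (1.20 log units; beyond the scatter) even though the two groups match in heavy-atom count and hydrogen-bond acceptors. Acetyl also improves on the other groups, with a 5.1-fold lower number from compound 2 to compound 4 (0.71 log units; beyond the scatter) and a 2.9-fold lower number from compound 1 to compound 4 (0.47 log units; beyond the scatter) making compound 4 the strongest inhibitor of the four.

Nothing available here explains why acetyl outperforms these groups. Going by these compounds, whether a carboxylic acid, an amide or a longer ketone chain at this position would match acetyl remains open.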